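The source may hold more compounds than are shown below. What is called first, only, known or untested is meant among the compounds shown, and "the series" means these compounds.

In an ADME assay on PC-12 cells (Rattus norvegicus) for cytotoxicity, read by MTT assay, with a stated time of 24 h (a higher number here means that more compound is tolerated, a lower number that less compound is tolerated), compound 1 `COc1cccc(N2CCN(CC#CCOC(=O)c3sc4ncnc(N5CCCCC5)c4c3C)CC2)c1` gives 144 ug/mL and compound 2 `Cc1c(C(=O)OCC#CCN2CCN(c3cc(C4CC4)ccc3C#N)CC2)sc2ncnc(N3CCCCC3)c12` gives 148 ug/mL, so compound 2 stands level with compound 1 within the scatter. Compound 3 `Cc1c(C(=O)OCC#CCN2CCN(c3ccc(Br)cc3C#N)CC2)sc2ncnc(N3CCCCC3)c12` carries 4-bromo-2-cyanophenyl in place of 2-cyano-5-cyclopropylphenyl on an amine nitrogen in a ring. For the measured compounds named here, the one measured step at this place, a 1.0-fold higher number from compound 1 to compound 2 (0.01 log units; within the scatter), stayed within the scatter, although it swapped one substituted phenyl group for another. No step beyond the scatter is therefore expected in this assay. The estimated change is a 1.0-fold lower number from compound 2 to compound 3 (0.01 log units; within the scatter). For compound 3 the expected value is 145 ug/mL, with an estimated range of 72 ug/mL to 290 ug/mL.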

Compound 3, half-maximal cytotoxic concentration: 136 ug/mL
Beside the measured number, compound 3's estimate is 1.1-fold (0.03 log units) above it; the measured number falls inside the stated range.
By their numbers in this assay, from the lowest: compounds 3, 1 and 2 (each within the scatter of the next).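

In this assay, a third substituted phenyl group on this amine nitrogen again moves the number only within the scatter (a 1.1-fold lower number from compound 2 to compound 3 (0.04 log units; within the scatter)), and the same holds against the methoxy compound (a 1.1-fold lower number from compound 1 to compound 3 (0.02 log units; within the scatter)). A bromine-bearing group therefore joins the cyclopropyl and methoxy groups as a change that leaves this read-out level, so the position has now held steady across three different phenyl groups. No measurement here offers a reason for this flat result. Still open, on these data alone, is whether a group without a phenyl ring, such as a plain ethyl chain, or a phenyl carrying a carboxylic acid, would shift the number. Changes elsewhere on the shared core also remain untested by these compounds.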